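Compound 3 to compound 4: same atoms, joined differently

A few compounds are considered here, and "the series" means these few. Any claim that something is new, unique, unknown or untested is made for them only; others in the source may bear on it.

For the measured compounds named here, in a physicochemical assay for solubility (a higher number here means a more soluble compound, a lower number a less soluble compound), compound 3 (`CCOc1ccc2c(c1)C(c1cnn(C)c1)=CN(C)C(=O)[C@@H]2C`) gives 143 ug/mL, the only actual number so far. Compound 1 (`C[C@H]1C(=O)N(C)C=Cc2cc(CN3CCCC3)ccc21`) reads >= 97 ug/mL, which is a limit. Compound 2 (`CCS(=O)(=O)c1ccc2c(c1)C(c1cnn(C)c1)=CN(C)C(=O)[C@@H]2C`) reads >= 222 ug/mL, also a limit. Compound 4 (`CCOc1ccc2c(c1)C(c1cn(C)cn1)=CN(C)C(=O)[C@@H]2C`) carries 1-methyl-1H-imidazol-4-yl in place of 1-methyl-1H-pyrazol-4-yl on a double-bonded ring carbon. Going by the values given here, the one measured step, an at least 1.5-fold lower number from compound 2 to compound 3 (0.19 log units; that floor lies within the scatter), lies within the scatter at its floor and changes a different place, so no measured step bears directly on this change. The expectation therefore rests on compound 3 at 143 ug/mL. No shift beyond the scatter is expected, and the estimated step is a 1.1-fold higher number from compound 3 to compound 4 (0.05 log units; within the scatter). The expected value for compound 4 is 160 ug/mL, with an estimated range of 75 ug/mL to 330 ug/mL.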

Compound 4, solubility: 117 ug/mL
For compound 4 the middle estimate is 1.4-fold (0.14 log units) above the measured one; low and high end bracket the measured number.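

On the double-bonded ring carbon of the seven-membered non-aromatic ring, 1-methyl-1H-imidazol-4-yl in place of 1-methyl-1H-pyrazol-4-yl gives a 1.2-fold lower number from compound 3 to compound 4 (0.09 log units; within the scatter) in this assay. For the compounds shown here, this is the first measured step at this position, and rejoining the same atoms of the five-membered aromatic ring, with ethoxy held constant, stays within the scatter. No available evidence bears on this result.

Open: whether a carboxylic acid or a primary amine on that five-membered ring would move the read-out beyond the scatter. On these data alone, also open: whether the same exchange stays within the scatter with ethylsulfonyl in place of ethoxy.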